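The compounds below may be only part of what the source reports. "The series", "measured", "known", "first", "only" and "open" are said of these compounds alone.

Measured compounds:
compound 1 `O=C(CCSc1nc2cc(Cl)ccc2o1)N1CCC1` gives 3.7 mL/min/g
compound 2 `Clc1ccc2oc(SCCCN3CCCC3)nc2c1` gives 1.9 mL/min/g
compound 3 `CN(CCC(=O)N1CCCC1)c1nc2cc(Cl)ccc2o1` gives 1.9 mL/min/g

Of the compounds shown here, three sharing one core have been measured in an ADME assay on microsomes from liver (Homo sapiens) for metabolic stability, read by LC-MS, using NADPH, with a stated time of 45 min, tested at 0.5 uM; a higher number here means faster removal of the compound, a lower number slower removal. Compound 1 gives the highest of the three numbers, yet a 1.9-fold lower number from compound 1 to compound 2 (0.29 log units; within the scatter) lies within the scatter, and compound 3, which differs from compound 1 in more than one place, also gives a value within the scatter of compound 1. The three measured values therefore cannot be told apart with confidence.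

Compound 4 `CC1CCCN1C(=O)CCSc1nc2cc(Cl)ccc2o1` has not yet been measured. It differs from compound 1 in one place: 2-methylpyrrolidin-1-yl in place of azetidin-1-yl on a carbonyl carbon. For the measured compounds named here, the only measured step at a comparable place is a 1.9-fold lower number from compound 1 to compound 2 (0.29 log units; within the scatter), in which (pyrrolidin-1-yl)methyl replaced (azetidin-1-yl)carbonyl and the number stayed within the scatter. Compound 4 keeps the carbonyl that this step removed and alters only the ring attached to it, so no step beyond the scatter is expected in this assay . The expected step is a 1.1-fold lower number from compound 1 to compound 4 (0.02 log units; within the scatter). Compound 4 is thus estimated at 3.5 mL/min/g, with a range from 1.5 mL/min/g to 8 mL/min/g.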

Compound 4, intrinsic clearance in a liver preparation (reported as CLH), per the amount of preparation that the assay uses: 8.5 mL/min/g
The estimate for compound 4 lay 2.4-fold (0.39 log units) below the measured number; the whole stated range lies below it.
By their numbers in this assay, from the lowest: compounds 2, 3 and 1 (each within the scatter of the next); then compound 4.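

In this assay, the group on the carbonyl carbon proves able to shift the number while the carbonyl itself stays in place: a 2.3-fold higher number from compound 1 to compound 4 (0.36 log units; beyond the scatter), a modest step, but the only one shown that lies beyond the scatter. The earlier step, a 1.9-fold lower number from compound 1 to compound 2 (0.29 log units; within the scatter), changed the carbonyl as well as the ring and did not show this, so the new result gives this position its first clear sign of sensitivity. The change replaces a four-membered ring with a five-membered ring carrying a methyl group, and nothing measured here explains why the compound is removed faster.

The ring size and the methyl group changed together in this single step, so the compounds shown cannot say which of them matters, or whether both are needed. Other groups on the same carbonyl carbon, such as morpholin-4-yl, piperidin-1-yl or a simple dimethylamino group, would show whether the higher number belongs to this one group or extends to others at this place.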